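The compounds below may be only part of what the source reports. "The series", "measured", "known", "first", "only" and "open" are said of these compounds alone.

Of the compounds shown here, three of a shared family have been measured in a functional assay on MCF7 cells (Homo sapiens) for cytotoxicity, read by MTT assay, with a stated time of 48 h; a lower number here means a stronger inhibitor, a higher number a weaker inhibitor. Compound 1 `Cc1cc(C)cc(-n2cc(COC(=O)c3cc4ccccc4[nH]3)nn2)c1` gives 30500 nM in this assay. Compound 3 `O=C(OCc1cn(-c2cccc(C(F)(F)F)c2)nn1)c1cc2ccccc2[nH]1` gives 16500 nM in this assay, and compound 2 `CCCCc1ccc(-n2cc(COC(=O)c3cc4ccccc4n3Cc3cn(-c4ccc(CCCC)cc4)nn3)nn2)cc1` gives 66900 nM in this assay. Among these three numbers compound 1 stands second highest: its value and that of compound 3 lie within the scatter of each other, so nothing can be read from the gap between them, while the value of compound 2 sits beyond the scatter on the higher, weaker side.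

Compound 4 `COc1ccc(-n2cc(COC(=O)c3cc4ccccc4[nH]3)nn2)cc1` has not yet been measured in this assay. It differs from compound 1 in one place: 4-methoxyphenyl in place of 3,5-dimethylphenyl on an aromatic nitrogen. Within the data shown here, no step between two measured compounds isolates this kind of exchange, so there is no direct precedent to lean on. Given that the three measured values all sit close together, the step from compound 1 to compound 4 is expected to be small, a 1.2-fold lower number from compound 1 to compound 4 (0.09 log units; within the scatter), and probably not beyond the scatter in either direction. Compound 4 is therefore expected to give about 25000 nM in this assay, with a plausible range from 8000 nM to 80000 nM.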

Compound 4, half-maximal inhibitory concentration: 16200 nM
For compound 4 the middle estimate is 1.5-fold (0.19 log units) above the measured one; measured number inside the range.
By their numbers in this assay, from the lowest: compounds 4, 3 and 1 (each within the scatter of the next); then compound 2.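

In this assay the exchange of 3,5-dimethylphenyl for 4-methoxyphenyl on the aromatic nitrogen gives a 1.9-fold lower number from compound 1 to compound 4 (0.27 log units; within the scatter) and so cannot be told apart from the ordinary spread of repeated measurements. Among these compounds, this is the first single-place comparison, and it shows that at this position a carbon-only pair of substituents can give way to a group with an oxygen and a hydrogen-bond acceptor without a readable shift in the cytotoxicity number. No independent measurement of any property of these two groups is at hand to interpret this step, which in any case is too small to call for a cause.

Because this single exchange alters both the substituent and its arrangement on the phenyl ring, the effect of each alone stays unresolved. Whether an amine or a carboxylic acid on that phenyl ring, or a longer alkyl chain in place of the ring itself, would move the number beyond the scatter remains open in the compounds shown.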